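Aryl ketone variation on a shared core: cytotoxicity notes

The source may hold more compounds than are shown below. What is called first, only, known or untested is meant among the compounds shown, and "the series" means these compounds.

Measured compounds:
compound 1 `COc1cc(-c2cc(/C=C/C(=O)c3ccc(N)cc3)[nH]n2)cc(OC)c1OC` — 76%
compound 2 `COc1cc(-c2cc(/C=C/C(=O)c3ccc(Cl)c(Cl)c3)[nH]n2)cc(OC)c1OC` — 73%

In a functional assay on A498 cells (Homo sapiens) for cytotoxicity, read by sulforhodamine B assay, with a stated time of 48 h, tested at 1 uM (on this read-out higher numbers stand for a weaker effect at the one concentration tested and lower numbers for a stronger effect), compound 1 gives 76% and compound 2 gives 73%. Of these two numbers, that of compound 2 is the smaller, with compound 1 nearest, but a number 3 percentage points lower from compound 1 to compound 2 (within the scatter) is within the scatter, so the two are not distinguished.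

Compound 3 `COc1ccc(C(=O)/C=C/c2cc(-c3cc(OC)c(OC)c(OC)c3)n[nH]2)cc1OC` differs from compound 2 in one place: 3,4-dimethoxyphenyl in place of 3,4-dichlorophenyl on a carbonyl carbon. Among the measured compounds shown here, the one measured step bearing on this, an exchange of the aryl group on the same carbonyl carbon, is a number 3 percentage points lower from compound 1 to compound 2 (within the scatter), which lies within the scatter. On that basis the expected step is a number 1 percentage points lower from compound 2 to compound 3 (within the scatter), that is, none beyond the scatter. Compound 3 is therefore expected to give 72% in this assay, with a range from 58% to 86%.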

Compound 3, a percentage reported as activity, at one concentration (the size of the read-out at that concentration, not a potency): 78%
For compound 3 the middle estimate is 6 percentage points below the measured one; low and high end bracket the measured number.
By their numbers in this assay, from the lowest: compounds 2, 1 and 3 (each within the scatter of the next).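

With 3,4-dimethoxyphenyl on a carbonyl carbon whose other neighbour is the double-bonded chain carbon, the read-out shows a number 5 percentage points higher from compound 2 to compound 3 (within the scatter) and a number 2 percentage points higher from compound 1 to compound 3 (within the scatter) in this assay. Replacing 3,4-dichlorophenyl adds hydrogen-bond acceptors and heavy atoms in the counts for the two groups, yet this exchange gives no step beyond the scatter, so the three aryl groups shown are not told apart here at the one concentration tested. No available evidence accounts for this result.

Open, from the compounds shown here alone, is whether a group of another kind at this place, such as a 4-carboxyphenyl, a cyclohexyl or a longer chain, would give a step beyond the scatter. Also open, going by these compounds, is whether compounds 1, 2 and 3 would separate in a full concentration series.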